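Ethyl to butyl on the cyclic phosphate series

This account rests on a few compounds, and the source may have more. Where it says the series, first, only, none or still open, it means among the compounds named here.

Going by the values given here, compound 1 `CCc1cn([C@H]2C[C@@H]3OP(=O)(O)OC[C@H]3O2)c(=O)[nH]c1=O` gives the lower of the two numbers so far: in a functional assay on Raji cells (Homo sapiens) (a higher number here means a weaker inhibitor, a lower number a stronger inhibitor), compound 1 gives 60 ug/mL. Compound 2 `CCCCCCc1cn([C@H]2C[C@H](O)[C@@H](CO)O2)c(=O)[nH]c1=O` carries a hexyl chain on a different sugar part, and in this assay compound 2 gives 151 ug/mL; the two values differ beyond the scatter, but the structures differ in more than one place, so no single step can be read from them.

Compound 3 `CCCCc1cn([C@H]2C[C@@H]3OP(=O)(O)OC[C@H]3O2)c(=O)[nH]c1=O` keeps the core of compound 1 and differs only by ethyl in place of hydrogen on a saturated chain carbon, two bonds along the chain from an aromatic carbon. Among the compounds with values here, no measured pair shows this change alone. A modest step is expected, weakening if anything, with the outcome possibly inside the scatter. The step from compound 1 to compound 3 in this assay is estimated at a 1.3-fold higher number from compound 1 to compound 3 (0.10 log units; within the scatter). Compound 3 is therefore expected to give about 75 ug/mL in this assay, within a range of 25 ug/mL to 250 ug/mL.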

Compound 3, concentration for 50% inhibition: 82 ug/mL
Estimate against measurement, compound 3: 1.1-fold (0.04 log units) below; low and high end bracket the measured number.
By their numbers in this assay, from the lowest: compounds 1, 3 and 2 (each within the scatter of the next, the first and the last beyond it).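

In this assay, going by these compounds alone, ethyl in place of hydrogen on a saturated chain carbon, two bonds along the chain from an aromatic carbon, gives the first step that can be read at one place (a 1.4-fold higher number from compound 1 to compound 3 (0.14 log units; within the scatter)). On the core of compound 1, the change from ethyl to butyl therefore leaves the number within the scatter, so this one pair shows no resolved effect of the added chain length at this position. Nothing measured here bears on the reason for this result.

As far as these compounds go, whether an octyl chain or a carboxylic acid in place of the butyl on the same core would move the number beyond the scatter remains open. Compound 2 carries its hexyl chain on a different sugar part, so it cannot show how the chain behaves on the cyclic phosphate core.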